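Working notes: extending the chain of compound 2

The compounds below may be only part of what the source reports. "The series", "measured", "known", "first", "only" and "open" are said of these compounds alone.

In an ADME assay on Vero cells (Chlorocebus sabaeus) for cytotoxicity (on this read-out higher numbers stand for lower toxicity in this test and lower numbers for higher toxicity in this test), compound 1 `CC(=O)Nc1nc(N)nc2c1ncn2[C@H]1CO[C@@H](CO)O1` gives > 100000 nM, which is a limit of the assay and not a number. For the measured compounds named here, compound 2 `CCCCCCCCCCCC(=O)Nc1nc(N)nc2c1ncn2[C@H]1CO[C@@H](CO)O1` gives 53000 nM, the only true number so far. Going by the values given here, the single measured step is an at least 1.8-fold lower number from compound 1 to compound 2 (0.27 log units; that floor lies within the scatter). It comes with decyl in place of hydrogen on a saturated chain carbon bound to a carbonyl carbon, and its floor lies within the scatter.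

Compound 3 `CCCCCCCC/C=C\CCCCCCCC(=O)Nc1nc(N)nc2c1ncn2[C@H]1CO[C@@H](CO)O1` differs from compound 2 by dec-1-en-1-yl in place of butyl on a saturated chain carbon, seven bonds along the chain from a carbonyl carbon. Among the compounds with values here, no measured step covers a double bond or a change between two long chains. Within the data shown here, the step of an at least 1.8-fold lower number from compound 1 to compound 2 (0.27 log units; that floor lies within the scatter) is the only guide, and it shows no shift beyond the scatter, so none is expected here in this assay, in either direction. The estimated change is a 1.1-fold lower number from compound 2 to compound 3 (0.03 log units; within the scatter). Compound 3 is expected at 50000 nM, with an estimated range of 20000 nM to 100000 nM.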

Compound 3, half-maximal cytotoxic concentration: 19000 nM
Compound 3: the middle estimate sits 2.6-fold (0.42 log units) above what was measured; the whole stated range lies above it.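

The exchange of butyl for dec-1-en-1-yl on a saturated chain carbon, seven bonds along the chain from a carbonyl carbon, comes with a 2.8-fold lower number from compound 2 to compound 3 (0.45 log units; beyond the scatter) in this assay. For the compounds shown here, this is the first step that lies beyond the scatter, and it shows that a change far out on the chain, with the shared core and the amide left as they are, can move this read-out towards higher toxicity in this test. Compound 1 stands at a limit and not at a number, so the earlier step gave only a floor and could not show this: the limit of > 100000 nM in this assay, at which 1 of the 3 values shown sits.

Compound 3 differs from compound 2 both in the size of the entering chain and in its double bond, so the step cannot be assigned to either one, and a saturated dec-1-yl group at the same place would separate the two. Also open, going by these compounds, is how the read-out responds to a longer chain still, or to an amine or a carboxylic acid at the far end of the chain.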